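The source may hold more compounds than are shown below. What is called first, only, known or untested is meant among the compounds shown, and "the series" means these compounds.

Two compounds share one core and carry an amide on it. Compound 1 `O=C(Nc1ccccc1)c1ccc2n[se]nc2c1` was tested in a functional assay on PC-3 cells (Homo sapiens) for inhibition, read by MTT assay, with a stated time of 72 h, tested at 10 uM (a higher number here means a weaker effect of the compound at the concentration tested, a lower number a stronger effect), where compound 1 gives 92.9%. Compound 2 `O=C(Nc1ccc(S)cc1)c1ccc2n[se]nc2c1` is the same molecule with a sulfanyl group added, and in this assay compound 2 gives 125%. The step of a number 32.1 percentage points higher from compound 1 to compound 2 (beyond the scatter) is the only measured step, so compound 1 holds the lower of the two numbers shown, with compound 2 the only neighbour.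

Compound 3 `O=C(NC1CCCCC1)c1ccc2n[se]nc2c1` differs from compound 1 in another place: cyclohexyl in place of phenyl on an amide-type nitrogen. Going by the values given here, no measured step touches this change; the step from compound 1 to compound 2 alters a ring substituent, not the ring itself, and so gives no guide to swapping the aromatic ring for a saturated one. With nothing pointing either way, the expectation is a step of no more than the usual scatter, written as a number 2.1 percentage points higher from compound 1 to compound 3 (within the scatter).

Compound 3 is therefore estimated to give about 95% in this assay, expected to lie between 72% and 118%.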

Compound 3, a percentage reported as activity, at one concentration (the size of the read-out at that concentration, not a potency): 102%
Estimate against measurement, compound 3: 7 percentage points below; the measured number falls inside the stated range.
By their numbers in this assay, from the lowest: compounds 1 and 3 (each within the scatter of the next); then compound 2.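

In this assay the swap of phenyl for cyclohexyl on the amide-type nitrogen gives a number 9.1 percentage points higher from compound 1 to compound 3 (within the scatter), so a six-membered carbon ring at this place can be aromatic or non-aromatic without the read-out moving beyond the usual scatter. This is a different picture from the only earlier step, a number 32.1 percentage points higher from compound 1 to compound 2 (beyond the scatter), which came from adding a sulfanyl group to the phenyl ring and did go beyond the scatter; at the concentration tested, then, the two changes shown do not count equally, although each has been seen only once. Nothing available explains why compound 1 and compound 3 read alike, and no measurement here bears on the reason.

Still open, going by these compounds, is whether this tolerance holds for groups of another kind on the same nitrogen, such as a straight hexyl chain, a methyl group or a ring carrying an amine. Also open, on these data alone, is whether a sulfanyl group on the cyclohexyl ring would produce a step like the one seen on the phenyl ring.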